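Swapping a phenyl for a cyclopropyl group

A few compounds are considered here, and "the series" means these few. Any claim that something is new, unique, unknown or untested is made for them only; others in the source may bear on it.

Of the compounds shown here, two with a shared core have been tested in a functional assay on K562 cells (Homo sapiens) for inhibition, read by fluorescence, with a stated time of 72 h; on this read-out lower numbers stand for stronger inhibition of growth and higher numbers for weaker inhibition of growth. Compound 1 `Cc1nc(C2CC2)cc2nn(-c3ccccc3)cc12` gives 25900 nM in this assay. Compound 2 `c1ccc(-c2cc3nn(-c4ccccc4)cc3cn2)cc1` gives 3400 nM in this assay, the lowest of the two numbers, and its gap to compound 1 lies beyond the usual scatter. Compound 3 `c1ccc(-n2cc3cnc(C4CC4)cc3n2)cc1` has not yet been measured; it differs from compound 2 by cyclopropyl in place of phenyl on an aromatic carbon. Among the measured compounds shown here, compound 1 carries the same cyclopropyl group together with a methyl group and gives 25900 nM, so no pair of measured compounds shows this change on its own. The expectation is that compound 3 loses potency, with a step of a 4.4-fold higher number from compound 2 to compound 3 (0.64 log units; beyond the scatter) beyond the scatter. The estimate for compound 3 in this assay is 15000 nM, within a range from 5000 nM to 45000 nM.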

Compound 3, concentration for 50% growth inhibition: 60500 nM
Beside the measured number, compound 3's estimate is 4.0-fold (0.61 log units) below it; the measured number lies above the stated range.
By their numbers in this assay, from the lowest: compound 2; then compound 1; then compound 3.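

In this assay, cyclopropyl in place of phenyl on the aromatic carbon next to the ring nitrogen gives an 18-fold higher number from compound 2 to compound 3 (1.25 log units; beyond the scatter) and so shows, with nothing else on the shared core altered, that growth inhibition depends strongly on which group sits at this position. Hydrogen in place of methyl on an aromatic carbon gives a 2.3-fold higher number from compound 1 to compound 3 (0.37 log units; beyond the scatter) and so shows that the methyl group of compound 1 also affects the read-out, though the step is modest. Nothing measured here bears on why either step has the size it does.

From the compounds shown here alone, only phenyl and cyclopropyl appear at this position, so it remains open how an amine, a longer alkyl chain or a carboxylic acid would fare there. Also open, going by these compounds, is whether adding the methyl group to compound 2 would produce a similar step.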